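The source may hold more compounds than are shown below. What is called first, only, known or untested is meant among the compounds shown, and "the series" means these compounds.

Compound 1 `COC(=O)c1ccc(NCc2cncn2Cc2ccc(OC)cc2)cc1-c1ccccc1` has no reported result in a toxicity assay on NIH3T3 cells (Mus musculus) for cytotoxicity, read by resazurin assay; on this read-out higher numbers stand for an effect only at larger amounts of compound and lower numbers for an effect already at smaller amounts; its entry in this assay reads "not determined" (no result reported). Going by the values given here, the only number at hand comes from compound 2 `CCc1ccc(Cn2cncc2CNc2ccc(-c3nc4ccccc4s3)c(-c3ccccc3)c2)cc1`, which in this assay gives a limit of > 1000 nM rather than a figure. Among the compounds with values here, that leaves compound 1 without any place on the scale, and the limit of > 1000 nM in this assay, at which 1 of the 2 values shown sits, is the sole guide to where this series sits. Compound 3 `COC(=O)c1ccc(NCc2cncn2Cc2ccccc2[N+](=O)[O-])cc1-c1ccccc1` carries 2-nitrophenyl in place of 4-methoxyphenyl on a saturated chain carbon bound to an aromatic nitrogen. Within the data shown here, with no measured step to draw on, any shift in this assay from compound 1 to compound 3 is expected to stay within the usual scatter. Compound 3 is therefore estimated at 3000 nM, between 800 nM and 20000 nM.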

Compound 3, half-maximal effective concentration: 10000 nM
Beside the measured number, compound 3's estimate is 3.3-fold (0.52 log units) below it; measured number inside the range.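

Going by these compounds alone, compound 1 has no reported result in this assay, and no step to compound 3 can be read from it. What the change from 4-methoxybenzyl to 2-nitrobenzyl does stays open, and the only further guide is a limit: the limit of > 1000 nM in this assay, at which 1 of the 3 values shown sits.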